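Swapping the ring on the piperazine nitrogen of a benzamide

A few compounds are considered here, and "the series" means these few. Any claim that something is new, unique, unknown or untested is made for them only; others in the source may bear on it.

Measured so far:
Compound 1, `Nc1ccccc1NC(=O)c1ccc(CSC(=S)N2CCN(c3ccccc3)CC2)cc1`: 27.5%
Compound 2, `Nc1ccccc1NC(=O)c1ccc(CSC(=S)N2CCN(C3CCCCC3)CC2)cc1`: 31.7%

Both compounds were tested in a functional assay on A-375 cells (Homo sapiens) for antiproliferative activity, read by CCK-8 assay, with a stated time of 72 h, tested at 2 uM; on this read-out higher numbers stand for a stronger effect at the one concentration tested and lower numbers for a weaker effect. Compound 2 gives the higher of the two numbers, but the step of a number 4.2 percentage points higher from compound 1 to compound 2 (within the scatter) is within the scatter, so the two compounds cannot be told apart on this evidence.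

Compound 3, `Nc1ccccc1NC(=O)c1ccc(CSC(=S)N2CCN(c3cnccn3)CC2)cc1`, has not yet been measured. It differs from compound 2 in one place: pyrazin-2-yl in place of cyclohexyl on an amine nitrogen in a ring. Among the compounds with values here, the only measured step that bears on this change is the one from compound 1 to compound 2, in which one six-membered ring on that nitrogen was replaced by another, and it stayed within the scatter. Since compound 3 again carries a six-membered ring at the same place, no step beyond the scatter is expected, and the number is estimated to be close to those of compounds 1 and 2.

The expected step for compound 3 is a number 2.7 percentage points lower from compound 2 to compound 3 (within the scatter). Compound 3 is therefore estimated at 29%, with a range from 17% to 41%.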

Compound 3, a percentage reported as inhibition, at one concentration (the size of the read-out at that concentration, not a potency): 29.1%
Beside the measured number, compound 3's estimate is 0.1 percentage points below it; the range from low to high includes it.
By their numbers in this assay, from the lowest: compounds 1, 3 and 2 (each within the scatter of the next).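

In this assay, putting pyrazin-2-yl in place of cyclohexyl on the ring's amine nitrogen gives a number 2.6 percentage points lower from compound 2 to compound 3 (within the scatter), and putting it in place of phenyl gives a number 1.6 percentage points higher from compound 1 to compound 3 (within the scatter). The earlier pair compared only rings of carbon, whereas this ring is aromatic, holds 2 nitrogen and brings 2 hydrogen-bond acceptors where cyclohexyl has 0, yet the three six-membered rings at this place still cannot be told apart on this read-out. There is no supporting evidence here that could explain why these exchanges leave the number inside the scatter.

From the compounds shown here alone, all three compounds carry a six-membered ring at this place, so it remains open whether a different kind of group on this nitrogen, such as a methyl group, a longer alkyl chain or a carboxylic acid, would give a step beyond the scatter. The numbers also come from one cell line at a single concentration, so they show only the size of the effect at that concentration and leave open whether any of these compounds would have a stronger or weaker effect at other concentrations.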